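This account rests on a few compounds, and the source may have more. Where it says the series, first, only, none or still open, it means among the compounds named here.

In a functional assay on MCF7 cells (Homo sapiens) for antiproliferative activity, read by MTT assay, with a stated time of 48 h (on this read-out higher numbers stand for weaker inhibition and lower numbers for stronger inhibition), compound 3 `CCc1cccc(C)c1-n1nncc1CN1C(=O)C2(C(C#N)=C(N)Oc3c(N)cc4nc5ccccc5nc4c32)c2ccccc21` is reported only as a limit, > 50000 nM. That value is the limit of > 50000 nM in this assay, at which 1 of the 3 values shown sits. Compound 1 `CCc1ccccc1-n1nncc1CN1C(=O)C2(C(C#N)=C(N)Oc3c(N)cc4nc5ccccc5nc4c32)c2ccccc21` gives 24600 nM in this assay, and compound 2 `N#CC1=C(N)Oc2c(N)cc3nc4ccccc4nc3c2C12C(=O)N(Cc1cnnn1-c1cccc(C(F)(F)F)c1)c1ccccc12` gives 31600 nM. Compound 4 `N#CC1=C(N)Oc2c(N)cc3nc4ccccc4nc3c2C12C(=O)N(Cc1cnnn1-c1c(Cl)cc(Cl)cc1Cl)c1ccccc12` differs from compound 3 by 2,4,6-trichlorophenyl in place of 2-ethyl-6-methylphenyl on an aromatic nitrogen. The earlier exchanges of the group on that aromatic nitrogen bear on this change: a 1.3-fold higher number from compound 1 to compound 2 (0.11 log units; within the scatter) and an at least 1.5-fold higher number from compound 2 to compound 3 (0.19 log units; that floor lies within the scatter), while an at least 2.0-fold higher number from compound 1 to compound 3 (0.30 log units; that floor lies within the scatter). None of those steps moved this assay beyond its scatter, so no step beyond the scatter is expected for compound 4 in either direction. Compound 4 is therefore estimated at 40000 nM, between 15000 nM and 100000 nM. The expected step is an at least 1.2-fold lower number from compound 3 to compound 4 (0.09 log units; that floor lies within the scatter).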

Compound 4, half-maximal inhibitory concentration: 37800 nM
Estimate against measurement, compound 4: 1.1-fold (0.02 log units) above; the range from low to high includes it.
By their numbers in this assay, from the lowest: compounds 1, 2 and 4 (each within the scatter of the next). At a limit, above all of these: compound 3.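

In this assay, 2,4,6-trichlorophenyl on the aromatic nitrogen adds a third substitution pattern that stays within the scatter of the earlier groups (a 1.2-fold higher number from compound 2 to compound 4 (0.08 log units; within the scatter); a 1.5-fold higher number from compound 1 to compound 4 (0.19 log units; within the scatter)). Read against a limit, the exchange of 2-ethyl-6-methylphenyl for 2,4,6-trichlorophenyl gives only a floor (an at least 1.3-fold lower number from compound 3 to compound 4 (0.12 log units; that floor lies within the scatter)), so its true size cannot be read: the limit of > 50000 nM in this assay, at which 1 of the 4 values shown sits.

All the groups shown on this nitrogen are substituted phenyl rings. In this assay, as far as these compounds go, it stays open how a phenyl ring bearing an amine or a carboxylic acid, or a longer alkyl chain in place of the ring, would read.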